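Swapping a benzyl for a phenoxy group on the shared core

The source may report more compounds than this note shows. Statements on the series, on what has been measured and on what is new or still open speak of the compounds shown alone.

Measured compounds:
- compound 1, `COc1ccc(F)cc1CNCCCNc1ccnc2cc(Cc3ccc(C#N)cc3)ccc12`: 6050 nM
- compound 2, `COc1cccc(CNCCCNc2ccnc3cc(CCC(C)C)ccc23)c1O`: 5390 nM
- compound 3, `COc1cccc(CNCCCNc2ccnc3cc(Cc4ccc(C#N)cc4)ccc23)c1O`: 7150 nM

All three values come from an ADME assay on HepG2 cells (Homo sapiens) for cytotoxicity, read by luminescence, CellTiter-Glo and ATP content, with a stated time of 72 h; on this read-out lower numbers stand for an effect already at smaller amounts and higher numbers for an effect only at larger amounts of compound. Compound 1 gives 6050 nM, the second highest of the three numbers; compound 2 sits nearest with 5390 nM, compound 3 furthest with 7150 nM, and every gap among them lies within the scatter. Compound 4, `COc1ccc(F)cc1CNCCCNc1ccnc2cc(Oc3ccc(Cl)cc3)ccc12`, has not yet been measured in this assay. It differs from compound 1 in one place: 4-chlorophenoxy in place of 4-cyanobenzyl on an aromatic carbon.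

Going by the values given here, the step that most bears on this change is the one from compound 2 to compound 3, which also replaced a group at this position of the shared core and gave a 1.3-fold higher number from compound 2 to compound 3 (0.12 log units; within the scatter). The other measured step, a 1.2-fold higher number from compound 1 to compound 3 (0.07 log units; within the scatter), changed a different part of the molecule and was likewise within the scatter. With all measured numbers so close together, no movement beyond the scatter is expected for compound 4 in this assay; the expected step is a 1.1-fold lower number from compound 1 to compound 4 (0.04 log units; within the scatter). Compound 4 is therefore estimated at 5500 nM, with a likely range from 2500 nM to 12000 nM.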

Compound 4, half-maximal effective concentration: 4500 nM
Beside the measured number, compound 4's estimate is 1.2-fold (0.09 log units) above it, and the stated range covers the measured number.
By their numbers in this assay, from the lowest: compounds 4, 2, 1 and 3 (each within the scatter of the next).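

In this assay, putting 4-chlorophenoxy in place of 4-cyanobenzyl gives a 1.3-fold lower number from compound 1 to compound 4 (0.13 log units; within the scatter). The earlier step at this position exchanged one carbon-linked group for another, whereas this one puts an oxygen rather than a carbon on the shared core and a chlorine rather than a nitrile on the outer ring, and even this double difference leaves the number within the scatter. Nothing available explains why the number stays so close.

On these data alone, since the link and the ring substituent differ together, their separate contributions remain unknown, and 4-cyanophenoxy would be the group that pulls them apart. As far as these compounds go, it also remains open whether a group of a different kind at this position, such as an amine or a carboxylic acid, would move the number beyond the scatter.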